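This account rests on a few compounds, and the source may have more. Where it says the series, first, only, none or still open, it means among the compounds named here.

Measured so far: compound 1 `Nc1cc(N)c2nc(-c3ccccc3)c(NCc3ccc(Cl)c(Cl)c3)nc2c1` gives 4470 nM in a functional assay on MDA-MB-231 cells (Homo sapiens) for inhibition, read by sulforhodamine B assay, with a stated time of 48 h; on this read-out lower numbers stand for stronger inhibition of growth and higher numbers for weaker inhibition of growth; compound 2 `COc1ccc(CNc2nc3cc(N)cc(N)c3nc2-c2ccccc2)cc1OC` gives 29500 nM.

Among the compounds with values here, compound 2 holds the highest of the two numbers; its only neighbour is compound 1, reached by a 6.6-fold higher number from compound 1 to compound 2 (0.82 log units; beyond the scatter). Compound 3 `COc1cc(CNc2nc3cc(N)cc(N)c3nc2-c2ccccc2)cc(OC)c1OC` differs from compound 2 by methoxy in place of hydrogen on an aromatic carbon. Within the data shown here, no measured step adds a methoxy to an already dimethoxylated ring; the one step on record, a 6.6-fold higher number from compound 1 to compound 2 (0.82 log units; beyond the scatter), exchanges the whole aryl pattern and does not bear directly on this change. The expected step is therefore none beyond the scatter, a 1.0-fold higher number from compound 2 to compound 3 (0.01 log units; within the scatter) being the estimate. Compound 3 is expected at about 30000 nM in this assay, within 12000 nM to 75000 nM.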

Compound 3, concentration for total growth inhibition: 15100 nM
The estimate for compound 3 lay 2.0-fold (0.30 log units) above the measured number; measured number inside the range.
By their numbers in this assay, from the lowest: compound 1; then compounds 3 and 2 (each within the scatter of the next).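

On the 3,4-dimethoxyphenyl ring, methoxy in place of hydrogen on an aromatic carbon, ortho to a methoxy group and meta to a large group, gives a step that stays within the scatter (a 2.0-fold lower number from compound 2 to compound 3 (0.29 log units; within the scatter)). This position therefore takes the added methoxy with no change that can be separated from repeat variation, so growth inhibition does not track the number of methoxy groups across this pair. No independent data bear on this result.

As far as these compounds go, it remains open whether an amine, a carboxylic acid or a longer alkoxy chain at this position would also leave the number within the scatter. From the compounds shown here alone, the same methoxy addition on the 3,4-dichlorophenyl ring also remains open.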